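Replacing an Imidazole with a Methylthiazole in an Anilide Series

This account rests on a few compounds, and the source may have more. Where it says the series, first, only, none or still open, it means among the compounds named here.

Measured so far:
- compound 1, `Cc1cc(C)c(-c2ncc[nH]2)cc1NC(=O)c1ccc(OCc2ccccn2)cc1`: 3.1
- compound 2, `Cc1cc(F)c(-c2ncc[nH]2)cc1NC(=O)c1ccc(OCc2ccccn2)cc1`: 3

Compound 1 and compound 2 share the same core and differ in one place only, a fluoro in place of methyl on an aromatic carbon. In a physicochemical assay for lipophilicity (a lower number here means a more polar compound, a higher number a more lipophilic compound), compound 1 gives 3.1 and compound 2 gives 3; the step from one to the other is a number 0.10 log units lower from compound 1 to compound 2 (within the scatter), so compound 1 stands highest of the two numbers by a margin that the scatter swallows.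

Compound 3, `Cc1csc(-c2cc(NC(=O)c3ccc(OCc4ccccn4)cc3)c(C)cc2C)n1`, has not yet been measured in this assay. Compared with compound 1 it carries 4-methyl-1,3-thiazol-2-yl in place of 1H-imidazol-2-yl on an aromatic carbon. Within the data shown here, the only measured step, a number 0.10 log units lower from compound 1 to compound 2 (within the scatter), concerns a different position and a much smaller exchange, so it gives little direct guidance; no measured pair here swaps one five-membered aromatic ring for another. With the exchange of a donor-bearing ring for a ring without a donor and with an added methyl, the step is expected to be larger than the one seen and upward: the estimate for compound 3 in this assay is 4.2, expected between 3.6 and 4.8, which would mean a step of a number 1.10 log units higher from compound 1 to compound 3 (beyond the scatter).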

Compound 3, distribution coefficient: > 3
Compound 3: a limit, no number (the forecaster's own chance of this, stated with the estimate: 10%); the middle value does not contradict the limit.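

In this assay compound 3 gives only a limit, > 3, and not a number. Among these compounds, no step from compound 1 to compound 3 can therefore be read. The compounds shown leave open how the exchange of 1H-imidazol-2-yl for 4-methyl-1,3-thiazol-2-yl shifts the reading, in which direction and by how much.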